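The source may report more compounds than this note shows. Statements on the series, on what has been measured and on what is new or still open speak of the compounds shown alone.

In a functional assay on A549 cells (Homo sapiens) for cytotoxicity, read by XTT assay, with a stated time of 72 h (a lower number here means a stronger inhibitor, a higher number a weaker inhibitor), compound 1 (`COc1ccc(Cc2cc(OC)c(OC)c(OC)c2)cc1N`) gives 31 nM. Compound 2 (`CCn1ccc2cc(Cc3ccc(OC)c(OC)c3OC)ccc21`) reads > 10000 nM, which is a limit and not a number. Compound 3 (`COc1ccc(C(O)c2ccc3c(ccn3C)c2)c(OC)c1OC`) reads > 10000 nM, which is also a limit and not a number. Compound 3 therefore stands at the limit of > 10000 nM in this assay, at which 2 of the 3 values shown sit, and its true value is not known. Compound 4 (`COc1ccc(Cc2ccc3c(ccn3C)c2)c(OC)c1OC`) differs from compound 3 by one change: hydrogen in place of hydroxy on a saturated chain carbon bound to two aromatic carbons. Among the measured compounds shown here, no measured pair shows this change in this assay, so only a small step towards a lower number is expected, and a reading at the limit remains likely. The expected change is an at least 1.2-fold lower number from compound 3 to compound 4 (0.09 log units; that floor lies within the scatter). For compound 4 the estimate is 8000 nM, with an expected range from 1500 nM to 30000 nM.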

Compound 4, half-maximal inhibitory concentration: 600 nM
The estimate for compound 4 lay 13-fold (1.12 log units) above the measured number; the whole stated range lies above it.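

In this assay, hydrogen in place of hydroxy on a saturated chain carbon bound to two aromatic carbons gives an at least 16-fold lower number from compound 3 to compound 4 (1.22 log units; beyond the scatter), so this carbon affects the reading. Hydrogen in place of methyl on a saturated chain carbon bound to an aromatic nitrogen gives an at least 16-fold lower number from compound 2 to compound 4 (1.22 log units; beyond the scatter), so a second place matters as well. Compound 2 and compound 3 each read at a limit and not a number, so both steps are floors and their full size is unknown: the limit of > 10000 nM in this assay, at which 2 of the 4 values shown sit.

The compounds shown leave open how a carbonyl or a fluorine would read on the carbon bound to two aromatic carbons. They also leave open how a propyl chain or a bare hydrogen would read on the aromatic nitrogen.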